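The source may hold more compounds than are shown below. What is called first, only, known or untested is meant among the compounds shown, and "the series" means these compounds.

Measured compounds:
- compound 1 `Nc1nc(-c2ccc(Cl)o2)nc2sc(CN3CCC(F)CC3)cc12`: 1080 nM in an assay on CHO-K1 cells for antagonist activity at adenosine receptor A1 (Homo sapiens), read by a beta-galactosidase reporter, with stated times of 15 min and 6 h; on this read-out higher numbers stand for weaker inhibition and lower numbers for stronger inhibition
- compound 2 `N#Cc1ccc(-c2nc(N)c3cc(CN4CCC(F)CC4)sc3n2)cc1`: 8430 nM in this assay
- compound 3 `N#Cc1ccc(-c2nc(N)c3cc(CN4CC=CC4)sc3n2)cc1`: 2350 nM in this assay

Among the three measured compounds, compound 2 gives the highest number in this assay, that is, the weakest inhibition; compound 3 comes nearest and compound 1 lies furthest away. The unmeasured compound 4 `COc1cccc(-c2nc(N)c3cc(CN4CCC(F)CC4)sc3n2)c1` keeps the shared core of compound 2 and changes only the aryl group attached to it: 3-methoxyphenyl in place of 4-cyanophenyl on an aromatic carbon.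

For the measured compounds named here, one measured step bears on this change, the swap of the same aryl position from compound 1 to compound 2, which gave a 7.8-fold higher number from compound 1 to compound 2 (0.89 log units; beyond the scatter). The other step, a 3.6-fold lower number from compound 2 to compound 3 (0.55 log units; beyond the scatter), changes a different part of the molecule and says little here. So the aryl group at this position clearly matters, and the cyanophenyl of compound 2 is the weaker choice of the two seen. Whether a methoxyphenyl behaves more like the furanyl of compound 1 or like the cyanophenyl is not shown by any measured pair, so the expectation is uncertain. A modest move toward stronger inhibition is expected, a 2.1-fold lower number from compound 2 to compound 4 (0.32 log units; beyond the scatter), in this assay. Compound 4 is therefore estimated at 4000 nM in this assay, within a range from 1000 nM to 16000 nM.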

Compound 4, inhibition constant: 3220 nM
Compound 4: middle estimate off by 1.2-fold (0.09 log units), on the high side, within the range that was stated.
By their numbers in this assay, from the lowest: compound 1; then compounds 3 and 4 (each within the scatter of the next); then compound 2.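

In this assay, the aryl position turns out to be graded rather than all-or-nothing: 3-methoxyphenyl gives a 2.6-fold lower number from compound 2 to compound 4 (0.42 log units; beyond the scatter), yet it does not match 5-chlorofuran-2-yl, with a 3.0-fold higher number from compound 1 to compound 4 (0.47 log units; beyond the scatter). The two phenyl groups compared here have equal counts of heavy atoms, hydrogen-bond donors and hydrogen-bond acceptors, so those counts alone do not set the number at this position. Nothing available here explains why these groups differ.

Still open, as far as these compounds go, is whether the difference follows the group itself or its place on the phenyl ring, a question that 3-cyanophenyl or 4-methoxyphenyl at this position would separate. Also open, from the compounds shown here alone, are how an unsubstituted phenyl or a 3-aminophenyl would rank, and whether 3-methoxyphenyl would have a similar effect alongside the amine ring of compound 3.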